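Aryl change on the sulfonyl ester, cytotoxicity on Vero cells

The compounds below may be only part of what the source reports. "The series", "measured", "known", "first", "only" and "open" are said of these compounds alone.

Compound 1, `O=c1cc(N2CCN(CC3CCC(OS(=O)(=O)c4cccnc4)CC3)CC2)sc2c([N+](=O)[O-])cc(C(F)(F)F)cc12`, is reported in an ADME assay on Vero cells (Chlorocebus sabaeus) for cytotoxicity, read by MTT assay, with a stated time of 48 h (on this read-out higher numbers stand for weaker inhibition and lower numbers for stronger inhibition), only as a limit, > 64 ug/mL.
Compound 2, `O=C(OC1CCC(CN2CCN(c3cc(=O)c4cc(C(F)(F)F)cc([N+](=O)[O-])c4s3)CC2)CC1)C1CCC1`, likewise gives only a limit in this assay, > 64 ug/mL.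
Compound 3, `O=c1cc(N2CCN(CC3CCC(OS(=O)(=O)c4ccc5ccccc5c4)CC3)CC2)sc2c([N+](=O)[O-])cc(C(F)(F)F)cc12`, also gives only a limit in this assay, > 64 ug/mL.

Compound 1 therefore stands at the limit of this assay rather than at a number, and the same is true of the two compounds derived from it: the limit of > 64 ug/mL in this assay, at which 3 of the 3 values shown sit. The step that the two limits leave unreadable from compound 1 to compound 2 and the step that the two limits leave unreadable from compound 1 to compound 3 cannot be read, since both ends are limits.

Compound 4, `O=c1cc(N2CCN(CC3CCC(OS(=O)(=O)c4ccc5c(c4)CCO5)CC3)CC2)sc2c([N+](=O)[O-])cc(C(F)(F)F)cc12`, differs from compound 1 as follows: a group of 9 heavy atoms (8 carbon, 1 oxygen; one five-membered non-aromatic ring with 1 hetero atom, one six-membered aromatic ring of carbon only) in place of a group of 6 heavy atoms (5 carbon, 1 nitrogen; one six-membered aromatic ring with 1 hetero atom), on a sulfonyl sulfur. The step from compound 1 to compound 3 is the measured step that resembles it most, as it also exchanges the group on the sulfonyl sulfur, and compound 3 stays at the limit; compound 2, which changes the ester instead, stays there too. Among the compounds with values here, no measured step gives a readable size, so no step beyond the scatter is expected in this assay in either direction, and the step that the limit leaves unreadable from compound 1 to compound 4 is expected to be small. Compound 4 is estimated at 100 ug/mL in this assay, most likely reported again as a limit, with a range from 50 ug/mL to 300 ug/mL.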

Compound 4, half-maximal inhibitory concentration: > 64 ug/mL
Compound 4 was reported as a limit (the forecaster's own chance of this, stated with the estimate: 85%); the middle value is on the limit's open side.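

Compound 4 also gives only a limit in this assay, > 64 ug/mL, so its steps from compound 1, compound 2 and compound 3 cannot be read, and all four compounds stand at the same limit: the limit of > 64 ug/mL in this assay, at which 4 of the 4 values shown sit.

The compounds shown leave open whether any of these exchanges alters cytotoxicity, and at what concentration any of the four would reach half-maximal inhibition.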